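The source may hold more compounds than are shown below. What is called first, only, known or untested is meant among the compounds shown, and "the series" means these compounds.

Of the compounds shown here, two built on one shared core have so far been tested in a functional assay on cells (Renal cancer cell line, Homo sapiens) for cytotoxicity, read by sulforhodamine B assay, with a stated time of 48 h; a lower number here means a stronger inhibitor of growth, a higher number a weaker inhibitor of growth. For the measured compounds named here, compound 1 `COc1nc2sc(C)cn2c1/C=C1/C(=O)Nc2ccccc21` is the first of them, and in this assay compound 1 gives 3530 nM. Compound 2 `O=C1Nc2ccccc2C1=Cc1c(-c2ccncc2)nc2sccn12` differs from compound 1 at more than one place, so the two cannot be read as a single step; in this assay compound 2 gives 14900 nM. Of these two numbers compound 1 has the lower, and the gap between them lies beyond the usual scatter of repeated measurements, so compound 1 is the stronger inhibitor of growth of the pair.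

Compound 3 `COc1nc2sc(C)cn2c1/C=C1/C(=O)Nc2ccc(O)cc21` comes next. It differs from compound 1 in one place only: hydroxy in place of hydrogen on an aromatic carbon. Going by the values given here, no measured pair so far shows what a change of this kind does in this assay, so no step size can be read off from the data. A modest step toward a lower number is expected, with a fair chance that it stays within the scatter; the estimated step is a 1.4-fold lower number from compound 1 to compound 3 (0.15 log units; within the scatter). For compound 3 the expected value in this assay is 2500 nM, with a range from 800 nM to 8000 nM.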

Compound 3, concentration for 50% growth inhibition: 6580 nM
Beside the measured number, compound 3's estimate is 2.6-fold (0.42 log units) below it; the measured number falls inside the stated range.
By their numbers in this assay, from the lowest: compounds 1 and 3 (each within the scatter of the next); then compound 2.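

For the compounds shown here, this is the first single-place step available in this assay, and placing hydroxy in place of hydrogen on an aromatic carbon of the six-membered aromatic ring of carbon only gives a 1.9-fold higher number from compound 1 to compound 3 (0.27 log units; within the scatter). A step of this size lies within the scatter, so compound 1 and compound 3 cannot be told apart here, and this one carbon, meta to a fused ring and para to a fused ring, carries a hydroxy group with no clear gain or clear loss in growth inhibition. Nothing at hand bears on how the hydroxy group acts in these cells.

The compounds shown leave open whether another group on this same carbon, such as a methoxy, an amine or a chlorine, would give a step beyond the scatter. They also leave open which of the several differences between compound 1 and compound 2 accounts for the gap in their numbers, and whether a hydroxy on the core of compound 2 would give a step of similar size.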